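The compounds below may be only part of what the source reports. "The series", "measured", "known", "first", "only" and "open" are said of these compounds alone.

Measured so far:
compound 1 `CCCCCCCCCCCCCCNC(=O)[C@@H](NC(=O)c1ccccc1)[C@@H](C)O`, 200000 nM;
compound 2 `CCCCCCCCCCCCCCNC(=O)[C@@H](NC(=O)c1ccco1)[C@@H](C)O`, 200000 nM;
compound 3 `CCCCCCCCCCCCCCNC(=O)[C@@H](NC(=O)c1cc2ccccc2o1)[C@@H](C)O`, 26700 nM.

In a functional assay on SW-620 cells (Homo sapiens) for cytotoxicity, read by MTT assay, with a stated time of 48 h (on this read-out higher numbers stand for weaker inhibition and lower numbers for stronger inhibition), compound 3 gives the lowest of the three numbers. Among the compounds with values here, the steps of a 7.5-fold lower number from compound 1 to compound 3 (0.87 log units; beyond the scatter) and a 7.5-fold lower number from compound 2 to compound 3 (0.87 log units; beyond the scatter) mark the 1-benzofuran-2-yl group as the only change that moved the read-out, whereas no change at the digits printed from compound 1 to compound 2 (within the scatter) shows no gain from the furan-2-yl group.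

Compound 4 `C/C=C/C=C/C(=O)N[C@H](C(=O)NCCCCCCCCCCCCCC)[C@@H](C)O` differs from compound 3 by penta-1,3-dien-1-yl in place of 1-benzofuran-2-yl on a carbonyl carbon. The bicyclic aromatic group that carried the whole gain leaves, and nothing measured speaks for the penta-1,3-dien-1-yl group. The expectation is therefore that the gain is given back, with a 5.6-fold higher number from compound 3 to compound 4 (0.75 log units; beyond the scatter). Compound 4 is estimated at 150000 nM, between 40000 nM and 300000 nM.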

Compound 4, half-maximal inhibitory concentration: 200000 nM
Compound 4: middle estimate off by 1.3-fold (0.12 log units), on the low side; the range from low to high includes it.
By their numbers in this assay, from the lowest: compound 3; then compounds 1, 2 and 4 (each within the scatter of the next).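

In this assay the penta-1,3-dien-1-yl group gives a 7.5-fold higher number from compound 3 to compound 4 (0.87 log units; beyond the scatter) and so loses the gain, while no change at the digits printed from compound 2 to compound 4 (within the scatter) and no change at the digits printed from compound 1 to compound 4 (within the scatter) put it level with furan-2-yl and phenyl. On this carbonyl carbon, a group with no ring therefore reads like the two single aromatic rings, and 1-benzofuran-2-yl alone stands apart. No measured evidence explains this difference. Within the data shown here, open is whether the gain needs the oxygen of 1-benzofuran-2-yl or only two fused aromatic rings, as naphthalen-2-yl or indol-2-yl would show.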